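From trifluoromethoxy to allyloxy in compound 1

The source may hold more compounds than are shown below. What is called first, only, known or untested is meant among the compounds shown, and "the series" means these compounds.

- Compound 1 (`COc1cc(NC(=O)/C=C/c2cccc(OC(F)(F)F)c2)cc(OC)c1OC`) with 4400 nM
- Compound 2 (`COc1ccccc1NC(=O)/C=C/c1cccc(OC(F)(F)F)c1`) with 9800 nM
- Compound 3 (`COc1ccc(NC(=O)/C=C/c2cc(OC)c(OC)c(OC)c2)cc1`) with > 50000 nM (a limit of the assay, not a number)

These values come from a functional assay on HeLa cells (Homo sapiens) for cytotoxicity, read by sulforhodamine B assay, with a stated time of 72 h (on this read-out lower numbers stand for stronger inhibition and higher numbers for weaker inhibition), and compound 1 holds the lowest of the numbers, with compound 2 higher by a gap beyond the usual scatter. Compound 4 (`C=CCOc1cccc(/C=C/C(=O)Nc2cc(OC)c(OC)c(OC)c2)c1`) keeps the core of compound 1 but carries allyl in place of trifluoromethyl on an oxygen on an aromatic ring so that trifluoromethoxy gives way to allyloxy. Going by the values given here, no measured pair shows this exchange, so any forecast is tentative. Since compound 1 at 4400 nM already holds the lowest number, a change is expected to lead upward in this assay rather than downward. The expected step of a 2.0-fold higher number from compound 1 to compound 4 (0.31 log units; beyond the scatter) is a moderate rise in the number. For compound 4 the estimated value is 9000 nM with an expected range from 3000 nM to 30000 nM at the upper end.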

Compound 4, half-maximal inhibitory concentration: 5400 nM
Beside the measured number, compound 4's estimate is 1.7-fold (0.22 log units) above it; low and high end bracket the measured number.
By their numbers in this assay, from the lowest: compounds 1, 4 and 2 (each within the scatter of the next, the first and the last beyond it). At a limit, above all of these: compound 3.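

Placing allyl in place of trifluoromethyl on an oxygen on an aromatic ring gives, in this assay, a 1.2-fold higher number from compound 1 to compound 4 (0.09 log units; within the scatter) and is the only comparison here in which just one place differs. The earlier compounds shown here could not isolate this position, whereas this pair shows that, on the core of compound 1, the two groups cannot be told apart in this read-out. They share no atoms, since the three fluorine atoms give way to an all-carbon group with a double bond, so on this core the fluorine atoms are not required to keep the reading of compound 1.

On these data alone, whether an amine, a carboxylic acid or a longer chain at this place would read the same remains open. Nothing given here explains why these two groups read alike.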